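The source may report more compounds than this note shows. Statements on the series, on what has been measured and on what is new or still open speak of the compounds shown alone.

Series notes, three measured members and one open position. In an assay on isolated protein for inhibition of Ectonucleotide pyrophosphatase/phosphodiesterase family member 1 (Homo sapiens), using Lineweaver-Burk analysis (a lower number here means a stronger inhibitor, a higher number a weaker inhibitor), compound 1 `COc1ccc(NC(=O)CSc2nc3c(OC(C)C)nc(N)nc3[nH]2)cc1OC` gives 89700 nM and stands highest of the three numbers. Compound 3 `COc1ccc(NC(=O)CSc2nc3nccnc3[nH]2)cc1OC` gives 30200 nM in this assay, the nearest value to compound 1 and beyond the scatter from it. Compound 2 `COc1ccc(NC(=O)CSc2nc3cc(Cl)cnc3[nH]2)cc1OC` gives 9780 nM in this assay, the furthest from compound 1. Compounds 2 and 3 carry different cores from compound 1, so they offer no single-change comparison. Compound 4 `COc1ccc(NC(=O)CSc2nc3c(SC)nc(N)nc3[nH]2)cc1OC` keeps the core of compound 1 and differs by one change: methylsulfanyl in place of isopropoxy on an aromatic carbon. For the measured compounds named here, no measured pair isolates this change, so no direction can be read from the data. The step from compound 1 to compound 4 is expected to be a 1.3-fold lower number from compound 1 to compound 4 (0.11 log units; within the scatter), not beyond the scatter. Compound 4 is thus estimated at 70000 nM in this assay, with a range from 25000 nM to 200000 nM.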

Compound 4, inhibition constant: 67900 nM
For compound 4 the middle estimate is 1.0-fold (0.01 log units) above the measured one, and the stated range covers the measured number.
By their numbers in this assay, from the lowest: compound 2; then compound 3; then compounds 4 and 1 (each within the scatter of the next).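

Methylsulfanyl in place of isopropoxy on this aromatic carbon gives a 1.3-fold lower number from compound 1 to compound 4 (0.12 log units; within the scatter) in this assay and so leaves the number effectively unchanged. For the compounds shown here, as the first single-change pair on the core of compound 1, it shows that this position takes either group, with the swap of oxygen for sulfur and the smaller group count staying within the scatter. Nothing on hand gives a reason for this flat step. As far as these compounds go, whether any group at this position can shift the number beyond the scatter stays open. An amine, a hydroxyl or a longer chain such as butoxy on the same carbon would test that.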